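The source may hold more compounds than are shown below. What is called first, only, known or untested is meant among the compounds shown, and "the series" means these compounds.

Measured compounds:
Compound 1, `CCCCC#CC(=O)[C@@H]1COC(C)(C)N1C(=O)OC(C)(C)C`, gives 9.08% in an assay on CHO cells for inhibition of sphingosine kinase 1 (Homo sapiens), tested at 10 uM; a lower number here means less inhibition, a higher number more inhibition at the concentration tested (going by the name of the read-out).
Compound 2, `CCCCC#C[C@@H](O)[C@@H](N)CO`, is reported in this assay as "not active" (no number reported), without a number.

For the measured compounds named here, compound 1 holds the only numeric value in this assay; compound 2 carries no number, so no step between measured compounds can be stated. Compound 1 therefore stands on its own, and its read-out is small.

Compound 3, `CCCCCCCCCCCCCC#CC(=O)[C@@H]1COC(C)(C)N1C(=O)OC(C)(C)C`, is not yet measured in this assay. It differs from compound 1 by nonyl in place of hydrogen on a saturated chain carbon, four bonds along the chain from a triple-bonded carbon. Going by the values given here, no measured pair shows what a change of this kind does in this assay, so the size of the step rests on judgement alone. The step expected here is a number 20.9 percentage points higher from compound 1 to compound 3 (beyond the scatter), upward and beyond the scatter. A result within the scatter of the value of compound 1 cannot be excluded. For compound 3 the estimate in this assay is 30%, with a range from 5% to 65%.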

Compound 3, a percentage reported as inhibition, at one concentration (the size of the read-out at that concentration, not a potency): 54.7%
The estimate for compound 3 lay 24.7 percentage points below the measured number; low and high end bracket the measured number.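

In this assay, for the compounds shown here, the saturated chain carbon four bonds along the chain from a triple-bonded carbon accepts a much larger group: nonyl in place of hydrogen gives a number 45.6 percentage points higher from compound 1 to compound 3 (beyond the scatter), the first step that can be read. The small read-out of compound 1 is thus not fixed by the shared core alone, as the chain alone separates the two compounds. Nothing measured here accounts for the size of this step.

As far as these compounds go, with one step, it remains open whether the read-out climbs steadily with chain length or peaks at some length, so a butyl or hexyl group in place of hydrogen, or a longer chain than that of compound 3, would be informative. Also open, from the compounds shown here alone, is how a chain ending in an amine or a carboxylic acid would read.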